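Iodo for methyl on the amide aryl ring

This account rests on a few compounds, and the source may have more. Where it says the series, first, only, none or still open, it means among the compounds named here.

Measured compounds:
compound 1 `COc1ccc(C(=O)Nc2ccc(C)c(Nc3nccc(-c4cccnc4)n3)c2)cc1OCCCCn1ccnc1`, 10100 nM
compound 2 `COc1ccc(C(=O)Nc2ccc(C)c(Nc3nccc(-c4cccnc4)n3)c2)c(OCCCCn2ccnc2)c1`, 58900 nM
compound 3 `Cc1ccc(OCCCCn2ccnc2)c(C(=O)Nc2ccc(C)c(Nc3nccc(-c4cccnc4)n3)c2)c1`, 59500 nM

In a functional assay on K562 cells (Homo sapiens) for cytotoxicity, read by XTT assay, with a stated time of 24 h (on this read-out higher numbers stand for weaker inhibition and lower numbers for stronger inhibition), compound 3 gives the highest of the three numbers. Compound 2 sits at a number within the scatter of compound 3, so no order between those two is claimed; compound 1 sits beyond the scatter, with the lower number. Compound 4 `Cc1ccc(NC(=O)c2cc(I)ccc2OCCCCn2ccnc2)cc1Nc1nccc(-c2cccnc2)n1` differs from compound 3 by iodo in place of methyl on an aromatic carbon. No step of this kind is shown among the measured compounds, so no size of effect can be read off. A step from compound 3 to compound 4 of about a 1.2-fold lower number from compound 3 to compound 4 (0.08 log units; within the scatter) is expected, within the scatter. Compound 4 is expected to give 50000 nM, in the range 15000 nM to 150000 nM.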

Compound 4, half-maximal inhibitory concentration: 66500 nM
The estimate for compound 4 lay 1.3-fold (0.12 log units) below the measured number, within the range that was stated.
By their numbers in this assay, from the lowest: compound 1; then compounds 2, 3 and 4 (each within the scatter of the next).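

In this assay, iodo in place of methyl on this aromatic carbon, para to a 4-(1H-imidazol-1-yl)butoxy group, gives a 1.1-fold higher number from compound 3 to compound 4 (0.05 log units; within the scatter). This is the only one-place step shown in the series, and it gives no measurable separation between these two groups at this position. No measured evidence bears on this result.

Going by these compounds, whether an amine or a carboxylic acid at this position would separate from methyl and iodo stays open. Also open, on these data alone, is whether a longer chain in place of the 4-(1H-imidazol-1-yl)butoxy group would change the number.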